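From compound 1 to its hydroxy analogue, compound 4

A few compounds are considered here, and "the series" means these few. Any claim that something is new, unique, unknown or untested is made for them only; others in the source may bear on it.

Among the compounds with values here, compound 1 `CC1(/C=C/c2ccccc2)C=CC(=O)O1` gives 414000 nM in a functional assay on NCI/ADR-RES cells (Homo sapiens) for inhibition, read by sulforhodamine B assay, with a stated time of 48 h (on this read-out higher numbers stand for weaker inhibition of growth and lower numbers for stronger inhibition of growth), and so holds the highest number among the three compounds measured so far. Compound 2 `CC1(/C=C/c2ccc(F)cc2)C=CC(=O)O1` stands at 25700 nM on the same read-out. Compound 3 `COc1cc(/C=C/C2(C)C=CC(=O)O2)cc(OC)c1OC` stands at 123000 nM there, and both of these lie beyond the scatter below compound 1.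

Compound 4 `CC1(/C=C/c2ccccc2O)C=CC(=O)O1` has not yet been measured. It departs from compound 1 in one place, hydroxy in place of hydrogen on an aromatic carbon with hydroxy in place of hydrogen on an aromatic carbon. Within the data shown here, only one measured step bears directly on this change. It is fluoro in place of hydrogen on an aromatic carbon, and it gave a 16-fold lower number from compound 1 to compound 2 (1.21 log units; beyond the scatter) in this assay which counts as large. Among the measured compounds shown here, compound 3 also sits lower than compound 1, but it offers no single-place step. For the measured compounds named here, no hydroxy compound has a measured value, so the fluoro step is only a loose guide to size. A lower number is still the likelier direction, with a smaller move than the fluoro step gave. The expected step is a 4.1-fold lower number from compound 1 to compound 4 (0.62 log units; beyond the scatter) in this assay as an estimate. For compound 4 the expected value is 100000 nM with an estimated range from 25000 nM to 350000 nM on this read-out.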

Compound 4, concentration for total growth inhibition: 78000 nM
Compound 4: the middle estimate sits 1.3-fold (0.11 log units) above what was measured; measured number inside the range.
By their numbers in this assay, from the lowest: compound 2; then compounds 4 and 3 (each within the scatter of the next); then compound 1.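

In this assay, hydroxy in place of hydrogen on an aromatic carbon, ortho to a group of 9 heavy atoms, gives a 5.3-fold lower number from compound 1 to compound 4 (0.72 log units; beyond the scatter), a modest step. Within the data shown here, this is the first single-place step that does not involve fluoro, so a lower number on this aromatic ring of compound 1 is no longer tied to that one group, although the fluoro change gave a 16-fold lower number from compound 1 to compound 2 (1.21 log units; beyond the scatter), a large step. Those two steps differ in both the group and its place on the ring, so they cannot separate the effect of one from the other, and no measurement shown here explains why either change lowers the number.

The compounds shown leave open whether hydroxy on another carbon of the ring would give a step of similar size, or whether fluoro at the place taken by hydroxy in compound 4 would give a large step. They also leave open how an amine, a carboxylic acid or a methoxy group alone on this same aromatic carbon would compare with hydroxy.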